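Sulfur-bound chains and growth inhibition: working notes

The source may report more compounds than this note shows. Statements on the series, on what has been measured and on what is new or still open speak of the compounds shown alone.

Measured so far in a functional assay on HT cells (Homo sapiens) for antiproliferative activity, read by fluorescence, with a stated time of 72 h (a lower number here means a stronger inhibitor of growth, a higher number a weaker inhibitor of growth), with these values:
- compound 1 `CC(C)c1n[nH]c2c(NCc3ccc(-c4ccccn4)cc3)nc(SCC(C)(C)O)nc12` gives 507 nM
- compound 2 `CC(C)c1n[nH]c2c(NCc3ccc(-c4ccccn4)cc3)nc(SCCCN)nc12` gives 120 nM

Compound 2 stands lowest of the two numbers, and its gap to compound 1 lies beyond the scatter. Compound 3 `CCC(CO)Sc1nc(NCc2ccc(-c3ccccn3)cc2)c2[nH]nc(C(C)C)c2n1` is the next to be read. Its change from compound 2 is 1-(hydroxymethyl)propyl in place of 3-aminopropyl on a sulfur and in words this is 1-(hydroxymethyl)propyl in place of 3-aminopropyl on a sulfur. Within the data shown here, the one measured step that bears on it is a 4.2-fold lower number from compound 1 to compound 2 (0.63 log units; beyond the scatter) and it is modest. There, 2-aminoethyl replaced 1-hydroxy-1-methylethyl on a saturated chain carbon bound to a sulfur, whereas compound 3 moves from an amino chain to a hydroxy chain. Among the measured compounds shown here, a single pair supports this, so a modest rise in the number is expected, no larger than that step. The estimated change is a 2.5-fold higher number from compound 2 to compound 3 (0.40 log units; beyond the scatter) on this reading. In this assay compound 3 is estimated at 300 nM with an expected range from 100 nM to 900 nM for now.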

Compound 3, concentration for 50% growth inhibition: 255 nM
For compound 3 the middle estimate is 1.2-fold (0.07 log units) above the measured one; the range from low to high includes it.
By their numbers in this assay, from the lowest: compound 2; then compounds 3 and 1 (each within the scatter of the next).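

In this assay, a 2.1-fold higher number from compound 2 to compound 3 (0.33 log units; beyond the scatter) on going from the 3-aminopropyl chain to 1-(hydroxymethyl)propyl on the sulfur, so a second hydroxy chain also stands apart from the one amino chain shown. Exchanging one hydroxy chain for the other gives a 2.0-fold lower number from compound 1 to compound 3 (0.30 log units; within the scatter) here, so 2-hydroxy-2-methylpropyl and 1-(hydroxymethyl)propyl are not separated in this read-out. No supporting data are available to account for the gap between the amino chain and the hydroxy chains.

Because the chains differ in more than the amine alone, the compounds shown leave open whether that gap follows the amine or the shape of the chain. An unbranched 3-hydroxypropyl chain, a longer 4-aminobutyl chain or a carboxylic acid on the sulfur would test this.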